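This account rests on a few compounds, and the source may have more. Where it says the series, first, only, none or still open, it means among the compounds named here.

Of the compounds shown here, two have so far been measured in an assay on cell membranes for binding affinity to 2-oxoglutarate receptor 1 (Rattus norvegicus), read by radioligand binding; on this read-out lower numbers stand for stronger inhibition and higher numbers for weaker inhibition. Within the data shown here, compound 1 `CCCCCCCCCCCNC(=O)[C@H]1OC(n2cnc3c(N)ncnc32)[C@H](O)[C@@H]1O` gives 123 nM, while compound 2 `NCCCCCCCCNC(=O)[C@H]1OC(n2cnc3c(N)ncnc32)[C@H](O)[C@@H]1O` gives 29 nM, the lowest of the two numbers; the only recorded step, a 4.2-fold lower number from compound 1 to compound 2 (0.63 log units; beyond the scatter), is the one comparison bearing on what follows. Compound 3 `CC(=O)NCCCCCCCCNC(=O)[C@H]1OC(n2cnc3c(N)ncnc32)[C@H](O)[C@@H]1O` differs from compound 2 by acetyl in place of hydrogen on an amine nitrogen. Because a 4.2-fold lower number from compound 1 to compound 2 (0.63 log units; beyond the scatter) was gained on introducing that free amine, capping it is expected to give back part of that gain, a step of a 2.8-fold higher number from compound 2 to compound 3 (0.44 log units; beyond the scatter). Compound 3 is therefore estimated at 80 nM, expected between 30 nM and 250 nM.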

Compound 3, inhibition constant: 10 nM
The estimate for compound 3 lay 8.0-fold (0.90 log units) above the measured number; measured number below the stated range.
By their numbers in this assay, from the lowest: compound 3; then compound 2; then compound 1.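

In this assay, putting acetyl on the amine nitrogen does not give back the earlier gain but extends it, with a 2.9-fold lower number from compound 2 to compound 3 (0.46 log units; beyond the scatter), so a free amino at this chain end is not needed for the lower number. Acetamido in place of propyl gives a 12-fold lower number from compound 1 to compound 3 (1.09 log units; beyond the scatter), the largest step among these compounds. Nothing measured here accounts for this result.

On these data alone, whether the carbonyl or the amide hydrogen of the acetamido carries the change remains open. So does how a urea, a methanesulfonamide, a carboxylic acid or a longer chain would read at this position.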